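The source may report more compounds than this note shows. Statements on the series, on what has been measured and on what is new or still open speak of the compounds shown alone.

In an in vitro ADME assay on microsomes from Gut (Homo sapiens) for metabolic stability, in the presence of a further agent that is not named here (on this read-out higher numbers stand for fast clearance and lower numbers for slow clearance), compound 1 (`COc1ccc(OC(F)(F)F)cc1Cn1c(C(=O)NCC(C)(C)CO)cc2cc(C#N)ccc21`) gives 68 mL.min-1.g-1. Compound 2 (`CCOc1ccc(OC(F)(F)F)cc1Cn1c(C(=O)NCC(C)(C)CO)cc2cc(C#N)ccc21`) gives 103 mL.min-1.g-1, and compound 3 (`COc1ccc(Br)cc1Cn1c(C(=O)NCC(C)(C)CO)cc2cc(C#N)ccc21`) gives 94 mL.min-1.g-1. Compound 1 therefore stands within the scatter of both of the others, and the numbers do not set it apart from either.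

Compound 4 (`COc1ccc(OC(F)(F)F)cc1Cn1c(C(=O)NCC2(CO)CC2)cc2cc(C#N)ccc21`) has not yet been measured. It differs from compound 1 in one place: 1-(hydroxymethyl)cyclopropyl in place of 1-(hydroxymethyl)-1-methylethyl on a saturated chain carbon bound to an amide-type nitrogen. The atoms of the 1-(hydroxymethyl)-1-methylethyl group are thus replaced by a 1-(hydroxymethyl)cyclopropyl group, while the rest of compound 1 stays as it is.

Neither measured step touches this place. Methyl in place of hydrogen on a saturated chain carbon bound to an oxygen on an aromatic ring gave a 1.5-fold higher number from compound 1 to compound 2 (0.18 log units; within the scatter). Bromo in place of trifluoromethoxy on an aromatic carbon gave a 1.4-fold higher number from compound 1 to compound 3 (0.14 log units; within the scatter). Within the data shown here, both steps lie within the scatter, so they bear on the new change only indirectly, and no measured compound carries the cyclopropyl ring. No step beyond the scatter is therefore expected in this assay, and the estimated step is a 1.0-fold lower number from compound 1 to compound 4 (0.02 log units; within the scatter). Compound 4 is expected to give 65 mL.min-1.g-1, within an estimated range of 35 mL.min-1.g-1 to 115 mL.min-1.g-1.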

Compound 4, intrinsic clearance in microsomes: 51 mL.min-1.g-1
Beside the measured number, compound 4's estimate is 1.3-fold (0.11 log units) above it; low and high end bracket the measured number.
By their numbers in this assay, from the lowest: compounds 4, 1, 3 and 2 (each within the scatter of the next, the first and the last beyond it).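

In this assay, putting 1-(hydroxymethyl)cyclopropyl in place of 1-(hydroxymethyl)-1-methylethyl on a saturated chain carbon bound to an amide-type nitrogen gives a 1.3-fold lower number from compound 1 to compound 4 (0.12 log units; within the scatter), so this read-out does not tell the two compounds apart. Among these compounds, the earlier steps touched only other places in the molecule, and this is the first reading at this position: the exchange brings in a three-membered ring of carbon only, keeps the same count of heavy atoms, donors and acceptors, and leaves the number within the usual scatter of compound 1. Nothing at hand accounts for the result or says what lies behind it.

The compounds shown leave open how much larger a change this position can take in this assay, for instance with a primary amine or a carboxylic acid in place of the hydroxymethyl group, or with a cyclobutyl ring in place of the cyclopropyl ring. They also leave open whether the same exchange would read the same way on compound 2 or compound 3, which carry the 1-(hydroxymethyl)-1-methylethyl group.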